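The source may report more compounds than this note shows. Statements on the series, on what has been measured and on what is new or still open speak of the compounds shown alone.

Measured so far in a functional assay on DU-145 cells (Homo sapiens) for antiproliferative activity, read by MTT assay, with a stated time of 24 h; a lower number here means a stronger inhibitor, a higher number a weaker inhibitor
compound 1 (`COc1ccc(-c2noc(C3CCCN3)n2)cc1OC1CCCC1`) gives 242000 nM
compound 2 (`COc1ccc(-c2noc(C3CCNCC3)n2)cc1OC1CCCC1`) gives 57 nM

Compound 2, at 57 nM in this assay, holds the lower of the two numbers. Compound 3 (`COc1ccc(-c2noc(-c3cccnc3)n2)cc1OC1CCCC1`) carries pyridin-3-yl in place of piperidin-4-yl on an aromatic carbon. Among the compounds with values here, the one measured step at this place is large (a 4200-fold lower number from compound 1 to compound 2 (3.63 log units; beyond the scatter)) and shows how far the number can move here, but no aromatic group has been measured there. A sizeable step to a higher number is therefore expected (a 53-fold higher number from compound 2 to compound 3 (1.72 log units; beyond the scatter)), though only loosely estimated. Compound 3 is expected at 3000 nM, with an estimated range from 150 nM to 60000 nM in this assay.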

Compound 3, half-maximal inhibitory concentration: > 1000000 nM
Compound 3 was reported as a limit; the forecaster's own chance of this, stated with the estimate: 10%; at least 330-fold (2.52 log units) between middle value and limit.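

With pyridin-3-yl, the only aromatic group shown at this place, this assay gives an at least 17000-fold higher number from compound 2 to compound 3 (4.24 log units; beyond the scatter), so the same count of heavy atoms does not preserve the number set by piperidin-4-yl. The change from pyrrolidin-2-yl also gives an at least 4.1-fold higher number from compound 1 to compound 3 (0.61 log units; beyond the scatter), which means that the two non-aromatic rings both give lower numbers than pyridin-3-yl. The value of compound 3 is a limit, not a number: the limit of > 1000000 nM in this assay, at which 1 of the 3 values shown sits.

The compounds shown do not separate the aromatic ring from the lost hydrogen-bond donor. Cyclohexyl at this place, or an aminomethyl group, would help tell these apart.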